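Bromo for chloro: a small step expected

The source may hold more compounds than are shown below. What is called first, only, known or untested is meant among the compounds shown, and "the series" means these compounds.

Of the compounds shown here, three have been tested in a functional assay on KB cells (Homo sapiens) for inhibition, read by MTT assay, with a stated time of 24 h, tested at 1 ug/mL; on this read-out lower numbers stand for less inhibition of growth and higher numbers for more inhibition of growth at the one concentration tested. Compound 1 (`CC(=O)SCCC(CCCCC(=O)O)SC(C)=O`) gives 12.4%. Compound 2 (`O=C(CCCCC1CCSS1)Nc1ccccn1`) is reported as "not active" (no number reported), without a number. Compound 3 (`O=C(CCCCC1CCSS1)Nc1ccc(Cl)cn1`) gives 0.76%, the lower of the two numbers, and its gap to compound 1 lies beyond the usual scatter.

Compound 4 (`O=C(CCCCC1CCSS1)Nc1ccc(Br)cn1`) has not yet been measured and differs from compound 3 in one place: bromo in place of chloro on an aromatic carbon. It carries bromo in place of chloro on an aromatic carbon. Among the measured compounds shown here, no measured pair differing in one place is available, so the expectation rests on the values alone. Compound 3 stands at 0.76%, close to no inhibition of growth, and compound 2 offers no number to suggest a larger effect. No step beyond the scatter is therefore expected in this assay. The estimated change, a number 2.2 percentage points higher from compound 3 to compound 4 (within the scatter), stays within the scatter. For compound 4 the expected value is 3%, with an estimated range from 0% to 12%.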

Compound 4, percent growth inhibition at one concentration: 4.33%
Compound 4: middle estimate off by 1.3 percentage points, on the low side; the measured number falls inside the stated range.
By their numbers in this assay, from the lowest: compounds 3, 4 and 1 (each within the scatter of the next, the first and the last beyond it).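

In this assay, the exchange of chloro for bromo on an aromatic carbon, two atoms from the ring nitrogen and para to a large group, gives a number 3.6 percentage points higher from compound 3 to compound 4 (within the scatter). Among the compounds shown here, this is the first step between two measured compounds that differ in one place, and it shows that this change of halogen does not separate compound 3 from compound 4 in this read-out at the one concentration tested. Nothing measured here explains this result.

Going by these compounds, whether an amine or a carboxylic acid on the same aromatic carbon would give a step beyond the scatter remains open. So does whether a longer chain in the shared core would do so, and how compound 3 and compound 4 would compare at other concentrations.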